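The source may report more compounds than this note shows. Statements on the series, on what has been measured and on what is new or still open speak of the compounds shown alone.

Compound 1 `COc1ccccc1/C=c1/[nH]c(=O)/c(=C\c2ccccc2OC)[nH]c1=O`: "not active" (no number reported); compound 2 `C=CCn1c(=O)/c(=C\c2cc(F)ccc2C)[nH]c(=O)/c1=C\c1ccccc1OC`: 7300 nM; compound 3 `C=CCn1c(=O)/c(=C\c2ccccc2OC)[nH]c(=O)/c1=C\c1ccccc1OC`: 21500 nM.

All three were tested in a functional assay on NCI-H1975 cells (Homo sapiens) for cytotoxicity, read by CCK-8 assay, with a stated time of 72 h (a lower number here means a stronger inhibitor, a higher number a weaker inhibitor), where compound 1 gave no number at all. Compound 3 has the higher of the two numbers; its nearest neighbour is compound 2, and the step of a 2.9-fold higher number from compound 2 to compound 3 (0.47 log units; beyond the scatter) was modest yet beyond the scatter. Compound 4 `C=CCn1c(=O)/c(=C\c2ccccc2C(F)(F)F)[nH]c(=O)/c1=C\c1ccccc1OC` differs from compound 3 by trifluoromethyl in place of methoxy on an aromatic carbon. For the measured compounds named here, the only measured step, a 2.9-fold higher number from compound 2 to compound 3 (0.47 log units; beyond the scatter), likewise exchanged the group on a double-bonded chain carbon and went towards a weaker compound as methoxy entered; exchanging a methoxy again is therefore expected to give a modest gain, so compound 4 is expected at a 2.2-fold lower number from compound 3 to compound 4 (0.33 log units; beyond the scatter). The estimate for compound 4 is 10000 nM, ranging from 3000 nM to 35000 nM.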

Compound 4, half-maximal inhibitory concentration: 14500 nM
Estimate against measurement, compound 4: 1.5-fold (0.16 log units) below, within the range that was stated.
By their numbers in this assay, from the lowest: compounds 2, 4 and 3 (each within the scatter of the next, the first and the last beyond it).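

Swapping methoxy for trifluoromethyl on this aromatic carbon gives a 1.5-fold lower number from compound 3 to compound 4 (0.17 log units; within the scatter) in this assay so the two groups cannot be told apart at this position. The 2-(trifluoromethyl)phenyl group likewise cannot be told apart from 5-fluoro-2-methylphenyl, with a 2.0-fold higher number from compound 2 to compound 4 (0.30 log units; within the scatter) even though compound 2 and compound 3 do separate from each other. As far as these compounds go, whether an amine or a carboxylic acid on this carbon would shift the number beyond the scatter stays open. No supporting measurement is available to explain why these numbers fall as they do.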